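The source may report more compounds than this note shows. Statements on the series, on what has been measured and on what is new or still open speak of the compounds shown alone.

Compound 1, `c1ccc(N2CCN(CCCCCOc3ccc4c(c3)CCC4)CC2)cc1`, gives 27% in a functional assay on the whole organism for inhibition, with Mus musculus as the target, at a dose of 25 mg/kg by the oral route; a lower number here means less inhibition, a higher number more inhibition at the dose given (going by the name of the read-out).
Compound 2, `Fc1cccc(N2CCN(CCCOc3ccc4c(c3)CCC4)CC2)c1`, gives 19% in this assay.

Compound 2 has the lower of the two numbers, yet the gap to compound 1 lies within the scatter, so the two cannot be ranked. Compound 3, `O=[N+]([O-])c1ccccc1N1CCN(CCCOc2ccc3c(c2)CCC3)CC1`, is not yet measured; it differs from compound 2 by 2-nitrophenyl in place of 3-fluorophenyl on an amine nitrogen in a ring. Among the measured compounds shown here, no measured pair shows what this kind of change does here. The step of a number 1 percentage points higher from compound 2 to compound 3 (within the scatter) that is expected from compound 2 to compound 3 is therefore small and not beyond the scatter. Compound 3 is estimated at 20%, with a range from 5% to 40%.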

Compound 3, a percentage reported as inhibition, in the whole organism at one dose (the size of the read-out at that dose, not a potency): 8%
Estimate against measurement, compound 3: 12 percentage points above; the measured number falls inside the stated range.
By their numbers in this assay, from the lowest: compound 3; then compounds 2 and 1 (each within the scatter of the next).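

With 2-nitrophenyl in place of 3-fluorophenyl on an amine nitrogen in a ring, this assay shows a number 11 percentage points lower from compound 2 to compound 3 (beyond the scatter) as a modest fall. This is the first step beyond the scatter among the compounds shown, so the group at this place can change the read-out at the dose given. Nothing shown here accounts for the fall. The swap changes both the substituent and the label of its ring position, so the two remain unseparated. A 3-nitrophenyl or 2-fluorophenyl group on the same nitrogen would tell them apart.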